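A few compounds are considered here, and "the series" means these few. Any claim that something is new, unique, unknown or untested is made for them only; others in the source may bear on it.

Working notes on the furan-substituted series.

Compound 1 `CCc1ccc(-c2nc(N)c3cc(Cc4ccccc4)sc3n2)o1` carries an ethyl group on the furan ring; in a functional assay on CHO-K1 cells for antagonist activity at adenosine receptor A1 (Homo sapiens), read by a beta-galactosidase reporter and cAMP accumulation, with stated times of 15 min and 6 h (on this read-out lower numbers stand for stronger inhibition and higher numbers for weaker inhibition), compound 1 gives 223 nM. Compound 2 `Nc1nc(-c2ccc(C3CC3)o2)nc2sc(Cc3ccccc3)cc12` carries a cyclopropyl group in the same place, and in this assay compound 2 gives 861 nM. Among the measured compounds shown here, the one step measured so far is a 3.9-fold higher number from compound 1 to compound 2 (0.59 log units; beyond the scatter). On the numbers at hand compound 2 thus stands as the weaker of the two measured compounds, with compound 1 as its nearest neighbour at a clearly lower number.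

Compound 3 `Nc1nc(-c2ccc(C(F)F)o2)nc2sc(Cc3ccccc3)cc12` is not yet measured. It differs from compound 2 by difluoromethyl in place of cyclopropyl on an aromatic carbon. For the measured compounds named here, no measured step bears directly on this exchange: the only step available, from ethyl to cyclopropyl, tells how this position responds to one change of a small carbon group and shows it is not indifferent, but it gives no direction for a difluoromethyl group. Given that, compound 3 is expected to stay in the range of compound 2, with the step of a 1.4-fold lower number from compound 2 to compound 3 (0.16 log units; within the scatter) estimated as small relative to the scatter. The estimate for compound 3 in this assay is 600 nM, within 200 nM to 2000 nM.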

Compound 3, inhibition constant: 3000 nM
Compound 3: middle estimate off by 5.0-fold (0.70 log units), on the low side; the whole stated range lies below it.
By their numbers in this assay, from the lowest: compound 1; then compound 2; then compound 3.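

In this assay the furan position proves more sensitive than the first pair showed: a 3.5-fold higher number from compound 2 to compound 3 (0.54 log units; beyond the scatter) is a step beyond the scatter, and the span of this position widens to a 13-fold higher number from compound 1 to compound 3 (1.13 log units; beyond the scatter), which makes compound 3 the weakest of the three and leaves compound 1 the strongest. Cyclopropyl and difluoromethyl both have 3 heavy atoms, 0 hydrogen-bond donors, 0 hydrogen-bond acceptors and no net charge, so these counts do not separate the two groups, although the numbers clearly do, and the position on the carbon next to the ring oxygen therefore responds to more than such counts capture. No measurement at hand accounts for the loss seen with difluoromethyl.

The compounds shown leave open whether the higher number of compound 3 goes with the fluorine atoms themselves or with the change of carbon group, a question that methyl and trifluoromethyl at the same place would bear on. They also leave open whether a longer chain such as propyl, or a polar group such as an amine, would continue the order seen from ethyl through cyclopropyl to difluoromethyl or break it.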